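The source may report more compounds than this note shows. Statements on the series, on what has been measured and on what is new or still open speak of the compounds shown alone.

Four close relatives share one core, an amide built from a nitrile-bearing double bond and a methoxybenzyl group, and differ only in the aromatic ring hung on that double bond and in one small substituent on it. Compound 1 `COc1ccc(CNC(=O)/C(C#N)=C/c2ccc(C)o2)cc1` carries a 5-methylfuran-2-yl ring; in a functional assay on A-431 cells (Homo sapiens) for inhibition, read by MTT assay, with a stated time of 72 h (a lower number here means a stronger inhibitor of growth, a higher number a weaker inhibitor of growth), compound 1 gives 58000 nM. Compound 2 `COc1ccc(CNC(=O)/C(C#N)=C/c2ccc(Cl)o2)cc1` differs from compound 1 by chloro in place of methyl on an aromatic carbon, and in this assay compound 2 gives 9000 nM, which is a 6.4-fold lower number from compound 1 to compound 2 (0.81 log units; beyond the scatter). Compound 3 `COc1ccc(CNC(=O)/C(C#N)=C/c2ccc(C)cc2)cc1` instead differs from compound 1 by 4-methylphenyl in place of 5-methylfuran-2-yl on a double-bonded chain carbon bound to a double-bonded chain carbon, and in this assay compound 3 gives 26000 nM, which is a 2.2-fold lower number from compound 1 to compound 3 (0.35 log units; beyond the scatter). Between compound 2 and compound 3 the step is a 2.9-fold higher number from compound 2 to compound 3 (0.46 log units; beyond the scatter).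

Compound 4 `COc1ccc(CNC(=O)/C(C#N)=C/c2ccc(Cl)cc2)cc1` has not been measured. It differs from compound 3 by chloro in place of methyl on an aromatic carbon. Among the measured compounds shown here, this is the same kind of change as the one from compound 1 to compound 2, but not the same: there the chloro sat on an aromatic carbon of a five-membered aromatic ring with 1 oxygen, next to the ring oxygen, two ring bonds from the ring atom that bears a large group, whereas here it sits on an aromatic carbon of a six-membered aromatic ring of carbon only, para to a large group. Because the earlier swap gave a 6.4-fold lower number from compound 1 to compound 2 (0.81 log units; beyond the scatter), a step in the same direction is expected here, though it may be smaller on the different ring, so the expected step is a 4.0-fold lower number from compound 3 to compound 4 (0.60 log units; beyond the scatter). Compound 4 is therefore estimated at 6500 nM, with a likely range from 2500 nM to 18000 nM.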

Compound 4, concentration for 50% growth inhibition: 6000 nM
The estimate for compound 4 lay 1.1-fold (0.03 log units) above the measured number; the measured number falls inside the stated range.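

The step from compound 3 to compound 4, a 4.3-fold lower number from compound 3 to compound 4 (0.64 log units; beyond the scatter), shows that chloro in place of methyl lowers the number on the core with the six-membered ring as well, and in this assay the two steps agree in size as well as in direction: the same change on two cores in this assay, a 6.4-fold lower number (0.81 log units; beyond the scatter) from compound 1 to compound 2 and a 4.3-fold lower number (0.64 log units; beyond the scatter) from compound 3 to compound 4, 1.5-fold (0.17 log units) apart, within the scatter of two such steps. With chloro in place on both rings, the ring swap gives a 1.5-fold lower number from compound 2 to compound 4 (0.18 log units; within the scatter), so compound 2 and compound 4 cannot be told apart here, while changing both the ring and the substituent at once gives a 9.7-fold lower number from compound 1 to compound 4 (0.99 log units; beyond the scatter). This supports carrying the change between these two cores in this one assay, but two cores make no general rule, and the numbers do not explain why chloro goes with the lower number.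

Going by these compounds, whether other groups in place of the chloro, such as bromo, trifluoromethyl or an amine, would continue this trend remains open. So does the effect of changing the methoxybenzyl part of the shared core, for example by putting a carboxylic acid in place of the methoxy group.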